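Methoxy for Methyl in a Level Series

A few compounds are considered here, and "the series" means these few. Any claim that something is new, unique, unknown or untested is made for them only; others in the source may bear on it.

In a functional assay on HL-60 cells (Homo sapiens) for cytotoxicity, read by MTT assay, with a stated time of 72 h (a lower number here means a stronger inhibitor, a higher number a weaker inhibitor), compound 1 `CC(=O)c1ccc(/N=C2\C=C(OCc3cn(S(=O)(=O)c4ccc(C)cc4)nn3)C(=O)c3ccccc32)cc1` gives 5300 nM, compound 2 `Cc1ccc(S(=O)(=O)n2cc(COC3=C/C(=N\c4ccc(Br)cc4)c4ccccc4C3=O)nn2)cc1` gives 4220 nM and compound 3 `Cc1ccc(/N=C2\C=C(OCc3cn(S(=O)(=O)c4ccc(C)cc4)nn3)C(=O)c3ccccc32)cc1` gives 5420 nM. Compound 3 thus stands within the scatter of both others. Compound 4 `COc1ccc(/N=C2\C=C(OCc3cn(S(=O)(=O)c4ccc(C)cc4)nn3)C(=O)c3ccccc32)cc1` differs from it in one place, methoxy in place of methyl on an aromatic carbon, para to a large group. Three measured steps exchange groups on that same carbon: a 1.3-fold lower number from compound 1 to compound 2 (0.10 log units; within the scatter), a 1.0-fold higher number from compound 1 to compound 3 (0.01 log units; within the scatter) and a 1.3-fold higher number from compound 2 to compound 3 (0.11 log units; within the scatter). All three lie within the scatter, so no change beyond the scatter is expected in this assay. The expected step is a 1.1-fold lower number from compound 3 to compound 4 (0.04 log units; within the scatter). Compound 4 is estimated at 5000 nM, with an expected range from 2800 nM to 9000 nM.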

Compound 4, half-maximal inhibitory concentration: 6960 nM
The estimate for compound 4 lay 1.4-fold (0.14 log units) below the measured number; measured number inside the range.
By their numbers in this assay, from the lowest: compounds 2, 1, 3 and 4 (each within the scatter of the next).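

In this assay, methoxy is a fourth group on this aromatic carbon, and it stays within the scatter of all three others (a 1.3-fold higher number from compound 3 to compound 4 (0.11 log units; within the scatter)), (a 1.6-fold higher number from compound 2 to compound 4 (0.22 log units; within the scatter)) and (a 1.3-fold higher number from compound 1 to compound 4 (0.12 log units; within the scatter)). Across compounds 1 to 4, then, methyl, bromo, acetyl and methoxy cannot be told apart at this position, even though only methoxy's entry adds an oxygen linked directly to the ring. Nothing available explains this flat response. The compounds shown leave open whether an amine, a carboxylic acid or a longer chain on this carbon would move the number beyond the scatter.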